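From thiophen-2-yl to 2,5-dimethylthiophen-3-yl on the shared core

The source may hold more compounds than are shown below. What is called first, only, known or untested is meant among the compounds shown, and "the series" means these compounds.

In a functional assay on cells (Cancer cell lines, Homo sapiens) for inhibition (a lower number here means a stronger inhibitor of growth, a higher number a weaker inhibitor of growth), compound 3 `N=C(N)N/N=C/c1c(-c2cccs2)nc2sccn12` gives 24000 nM, which lies within the scatter of compound 2 `N=C(N)N/N=C/c1c(-c2ccsc2)nc2sccn12` at 29500 nM. Compound 1 `Cc1cc(-c2nc3sc(C)cn3c2/C=N/NC(=N)N)c(C)s1`, which also carries 2,5-dimethylthiophen-3-yl, gives 11700 nM, a lower number than compound 3 by more than the scatter. Compound 4 `Cc1cc(-c2nc3sccn3c2/C=N/NC(=N)N)c(C)s1` has 2,5-dimethylthiophen-3-yl in place of the thiophen-2-yl of compound 3 on an aromatic carbon: 2,5-dimethylthiophen-3-yl in place of thiophen-2-yl on an aromatic carbon. Going by the values given here, the only measured step, a 1.2-fold lower number from compound 2 to compound 3 (0.09 log units; within the scatter), stays within the scatter and does not involve the dimethyl substitution. The nearest guide is therefore compound 1 at 11700 nM, so a modest move to a lower number is expected. For compound 4 the estimated step is a 1.6-fold lower number from compound 3 to compound 4 (0.20 log units; within the scatter). Compound 4 is expected at 15000 nM, within an estimated range of 8000 nM to 29000 nM.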

Compound 4, concentration for total growth inhibition: 32400 nM
Compound 4: middle estimate off by 2.2-fold (0.33 log units), on the low side, and the stated range ends below it.
By their numbers in this assay, from the lowest: compound 1; then compounds 3, 2 and 4 (each within the scatter of the next).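

In this assay, 2,5-dimethylthiophen-3-yl on this aromatic carbon stays within the scatter of both unmethylated thiophenes (a 1.4-fold higher number from compound 3 to compound 4 (0.13 log units; within the scatter); a 1.1-fold higher number from compound 2 to compound 4 (0.04 log units; within the scatter)), so the added thiophene methyls bring no gain in growth inhibition. The lower number of compound 1 instead goes with its methyl on an aromatic carbon of the core (a 2.8-fold higher number from compound 1 to compound 4 (0.44 log units; beyond the scatter)). Nothing shown here gives a cause for these steps.

From the compounds shown here alone, whether that core methyl gives a similar step alongside thiophen-2-yl remains open. So does what an ethyl or methoxy group would do on that carbon.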